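The compounds below may be only part of what the source reports. "The series", "measured", "known", "first", "only" and "open" are said of these compounds alone.

Measured compounds in an ADME assay on microsomes from liver (Homo sapiens) for metabolic stability, read by LC-MS, using NADPH, with a stated time of 45 min, tested at 0.5 uM; a higher number here means faster removal of the compound, a lower number slower removal:

Compound 1, `CS(=O)(=O)C1CCN(C(=O)CCSc2nc3cc(Cl)ccc3o2)C1`: < 0.4 mL/min/g, a limit of the assay rather than a number.
Compound 2, `CC1CCCN1C(=O)CCSc1nc2cc(Cl)ccc2o1`: 8.5 mL/min/g.
Compound 3, `CC(CC(=O)N1CCCC1)Sc1nc2cc(Cl)ccc2o1`: 8.6 mL/min/g.

All three share the same core and differ only in the amide part. Compound 2 stands lowest of the two numbers reported, but compound 3 lies within the usual scatter of it, so the two cannot be told apart. Compound 1 sits at the limit of < 0.4 mL/min/g in this assay, at which 1 of the 3 values shown sits; that result is a limit and not a number.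

Compound 4, `O=C(CCSc1nc2cc(Cl)ccc2o1)N1CCC1`, has not yet been measured in this assay. Relative to compound 2 it carries azetidin-1-yl in place of 2-methylpyrrolidin-1-yl on a carbonyl carbon. No pair of measured compounds that differ in a single place is available, so the size of this kind of step has no measured precedent among these compounds. With compound 2 giving 8.5 mL/min/g, and nothing to suggest a large shift, a step from compound 2 to compound 4 of a 1.4-fold lower number from compound 2 to compound 4 (0.15 log units; within the scatter) is expected, that is, little change beyond the scatter, possibly a small move toward slower removal. Compound 4 is therefore estimated at 6 mL/min/g, within a range from 2.5 mL/min/g to 14 mL/min/g.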

Compound 4, intrinsic clearance in a liver preparation (reported as CLH), per the amount of preparation that the assay uses: 3.7 mL/min/g
Estimate against measurement, compound 4: 1.6-fold (0.21 log units) above; the range from low to high includes it.
By their numbers in this assay, from the lowest: compound 4; then compounds 2 and 3 (each within the scatter of the next). At a limit, below all of these: compound 1.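

In this assay, this is the first pair among these compounds that differs in a single place, so the size of a change here can now be read: azetidin-1-yl in place of 2-methylpyrrolidin-1-yl on a carbonyl carbon gives a 2.3-fold lower number from compound 2 to compound 4 (0.36 log units; beyond the scatter), a move toward slower removal. It shows that swapping this ring alone, with the shared core and the saturated chain carbon on the carbonyl left as they are, is enough to shift the clearance measurably, though the step is modest. Nothing measured here explains why the change has this effect.

The step shrinks the ring and removes the methyl group at the same time, so the compounds shown leave open what each contributes, and an unsubstituted pyrrolidin-1-yl on this same chain would be needed to separate the two. Also open, going by these compounds, is whether a larger ring such as piperidin-1-yl or morpholin-4-yl, or an open-chain dimethylamino group, would continue or reverse the move, and how any of these would compare with compound 1, whose result is a limit and not a number.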